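A few compounds are considered here, and "the series" means these few. Any claim that something is new, unique, unknown or untested is made for them only; others in the source may bear on it.

Series notes. Compound 1 `O=C(Nc1cccc(-n2cc(-c3ccncc3)c(-c3cc(O)cc(Cl)c3)n2)c1)Nc1ccc(Cl)c(Cl)c1` carries a urea on the shared core; compound 2 `COc1cc(Cl)cc(-c2nn(-c3cccc(NC(=O)Nc4ccc(Cl)c(Cl)c4)c3)cc2-c2ccncc2)c1` differs from it by methyl in place of hydrogen on an oxygen on an aromatic ring. In a functional assay on NCI-H460 cells (Homo sapiens) for inhibition, read by sulforhodamine B assay, with a stated time of 48 h, tested at 10 uM (a lower number here means a stronger effect, a higher number a weaker effect of the compound at the concentration tested), compound 1 gives 0.21%, and compound 2 gives 3.1%; the step of a number 2.9 percentage points higher from compound 1 to compound 2 (within the scatter) is within the scatter. Compound 3 `O=C(Nc1cccc(-n2cc(-c3ccncc3)c(-c3cc(O)cc(Cl)c3)n2)c1)c1cc(C(F)(F)F)cc(C(F)(F)F)c1` replaces the urea with an amide; in this assay compound 3 gives 19.9%, the highest number of the three, beyond the scatter from both compound 1 and compound 2. The difference between the cores of compound 1 and compound 3 is not broken down here. Compound 4 `COc1cc(Cl)cc(-c2nn(-c3cccc(NC(=O)c4cc(C(F)(F)F)cc(C(F)(F)F)c4)c3)cc2-c2ccncc2)c1` differs from compound 3 by methyl in place of hydrogen on an oxygen on an aromatic ring, the same change as from compound 1 to compound 2. Since that change gave a number 2.9 percentage points higher from compound 1 to compound 2 (within the scatter), a similarly small step is expected, a number 3.1 percentage points higher from compound 3 to compound 4 (within the scatter), with wide uncertainty given the different core. Compound 4 is estimated at 23%, between 8% and 42%.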

Compound 4, a percentage reported as activity, at one concentration (the size of the read-out at that concentration, not a potency): 41%
The estimate for compound 4 lay 18 percentage points below the measured number; the range from low to high includes it.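

Methyl in place of hydrogen on the oxygen, hydroxy to methoxy, does not carry over from one core to the other at the same size in this assay: the same change on two cores in this assay, a number 2.9 percentage points higher (within the scatter) from compound 1 to compound 2 and a number 21.1 percentage points higher (beyond the scatter) from compound 3 to compound 4, 18.2 percentage points apart, beyond the scatter of two such steps

On the core of compound 3 the change gives a number 21.1 percentage points higher from compound 3 to compound 4 (beyond the scatter), so a small step on one core does not predict a small step on the other. With one pair on each core, this shows that the step can differ between these two cores, but not which part of the difference between compound 1 and compound 3 sets its size.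

Open, as far as these compounds go, is whether an ethyl group or a longer chain on that oxygen would follow either step. Also open, from the compounds shown here alone, is how an amine in place of the hydroxy would read on these cores.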